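The compounds below may be only part of what the source reports. "The series", "measured", "known", "first", "only" and "open" are said of these compounds alone.

Working notes on the series. Compound 1 `CC(C)Cc1ccc(C(C)C(=O)NCc2ccc(Cl)cc2)cc1` gives 27000 nM in an assay on brain for inhibition of Fatty-acid amide hydrolase 1 (Rattus norvegicus), read by scintillation counting, with a stated time of 10 min; on this read-out lower numbers stand for stronger inhibition and higher numbers for weaker inhibition. Compound 2 `CC(C)Cc1ccc(C(C)C(=O)NCc2ccccc2Cl)cc1` gives 4100 nM, the change being a 6.6-fold lower number from compound 1 to compound 2 (0.82 log units; beyond the scatter). Compound 3 `CC(C)Cc1ccc(C(C)C(=O)N2CCN(c3cccc(Cl)c3)CC2)cc1` gives 1700 nM, the lowest of the three numbers; compound 2 is nearest and compound 1 furthest. Compound 4 `Cc1cccc(N2CCN(C(=O)C(C)c3ccc(CC(C)C)cc3)CC2)c1` differs from compound 3 by methyl in place of chloro on an aromatic carbon, read one bond further out as 3-chlorophenyl to 3-methylphenyl. Going by the values given here, no measured step exchanges these two groups; the only step so far, from compound 1 to compound 2, moves a chloro around the ring and is of no direct bearing. A step of no more than the scatter, a 1.5-fold higher number from compound 3 to compound 4 (0.17 log units; within the scatter), is therefore expected. Compound 4 is estimated at 2500 nM, within 800 nM to 8000 nM.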

Compound 4, half-maximal inhibitory concentration: 16000 nM
The estimate for compound 4 lay 6.4-fold (0.81 log units) below the measured number; the whole stated range lies below it.
By their numbers in this assay, from the lowest: compound 3; then compound 2; then compounds 4 and 1 (each within the scatter of the next).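

The exchange of one heavy atom for one heavy atom at this aromatic carbon, meta to a large group, is not neutral: methyl in place of chloro gives a 9.4-fold higher number from compound 3 to compound 4 (0.97 log units; beyond the scatter) and so removes most of the advantage of compound 3. The earlier step moved a chloro around a ring, whereas this one holds the position and changes the group, showing that the identity of the group here matters. Nothing available explains the size of this step.

On these data alone, whether the preference is specific to chloro remains open. Fluoro, bromo, methoxy or trifluoromethyl on the same carbon would show how far it extends.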